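The compounds below may be only part of what the source reports. "The series", "measured", "known", "first", "only" and "open" are said of these compounds alone.

Measured compounds:
compound 1 `CNC(=O)N1CCCc2ccc(NC(=O)c3ccc(-c4cc[nH]n4)cc3)cc21`, 92.5%
compound 2 `CNC(=O)N1CCCc2ccc(NC(=O)c3cccc(-c4cn[nH]c4)c3)cc21`, 27.9%
compound 3 `CNC(=O)N1CCCc2ccc(NC(=O)c3ccccc3-c3ccccc3)cc21`, 10.7%

In a functional assay on MV4-11 cells (Homo sapiens) for antiproliferative activity, with a stated time of 6 days, tested at 1.56 uM (on this read-out higher numbers stand for a stronger effect at the one concentration tested and lower numbers for a weaker effect), compound 2 stands second highest of the three; compound 3 lies below it beyond the scatter, and compound 1 lies far above it, also beyond the scatter. Among the measured compounds shown here, no single-change step between measured compounds is available.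

Compound 4 `CNC(=O)N1CCCc2ccc(NC(=O)c3cccc(-c4ccn(C(C)=O)n4)c3)cc21` differs from compound 2 by 1-acetyl-1H-pyrazol-3-yl in place of 1H-pyrazol-4-yl on an aromatic carbon. The group enters on an aromatic carbon of a six-membered carbon-only ring, meta to a large group, and the hydrogen-bond donor of the ring that leaves is gone. For the measured compounds named here, no measured pair informs this change directly, so in this assay no step beyond the scatter is expected in either direction, a number 4.1 percentage points higher from compound 2 to compound 4 (within the scatter).

For compound 4 the estimate in this assay is 32%, expected between 8% and 62%.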

Compound 4, a percentage reported as inhibition, at one concentration (the size of the read-out at that concentration, not a potency): 27.6%
The estimate for compound 4 lay 4.4 percentage points above the measured number; the measured number falls inside the stated range.
By their numbers in this assay, from the lowest: compound 3; then compounds 4 and 2 (each within the scatter of the next); then compound 1.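

In this assay, placing 1-acetyl-1H-pyrazol-3-yl in place of 1H-pyrazol-4-yl on this aromatic carbon, meta to a large group, gives a number 0.3 percentage points lower from compound 2 to compound 4 (within the scatter). At this position, then, losing the hydrogen-bond donor of the ring and adding the acetyl together produce no step beyond the scatter. No measurement at hand explains this result.

Going by these compounds, the attachment point of the ring and the acetyl change together here, so their separate contributions stay open. Also open, on these data alone, is how a methyl on the ring nitrogen or an amine at this position would read.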